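Replacing the 4,4-dimethylpiperidin-1-yl group at high clearance

A few compounds are considered here, and "the series" means these few. Any claim that something is new, unique, unknown or untested is made for them only; others in the source may bear on it.

Measured in an ADME assay on microsomes from liver (Homo sapiens) for metabolic stability, read by LC-MS, with a stated time of 40 min, tested at 0.5 uM (a higher number here means faster removal of the compound, a lower number slower removal), so far:
Compound 1 `CC(C)S(=O)(=O)c1cccc(NC(=O)c2cccnc2N2CCC3(CC2)CC3)c1` gives 375 mL.min-1.g-1
Compound 2 `CC1(C)CCN(c2ncccc2C(=O)Nc2cccc(S(=O)(=O)C3CCCC3)c2)CC1` gives > 399 mL.min-1.g-1 as a limit

Compound 2 stands at the limit of > 399 mL.min-1.g-1 in this assay, at which 1 of the 2 values shown sits, and so carries a limit, not a number. Compound 3 `O=C(Nc1cccc(S(=O)(=O)C2CCCC2)c1)c1cccnc1N1CCC2(CC1)CC2` differs from compound 2 in one place, as follows: a group of 8 heavy atoms (7 carbon, 1 nitrogen; one three-membered non-aromatic ring of carbon only, one six-membered non-aromatic ring with 1 hetero atom) in place of a group of 8 heavy atoms (7 carbon, 1 nitrogen; one six-membered non-aromatic ring with 1 hetero atom), on an aromatic carbon and the rest of the structure stays the same. The change sits on an aromatic carbon of a six-membered aromatic ring with 1 nitrogen, next to the ring nitrogen. For the measured compounds named here, no measured step shows this change directly, so the expectation rests on little. Compound 1 also reads high at 375 mL.min-1.g-1 in this assay and this gives no reason to expect a step beyond the usual scatter in either direction. The expected step is an at least 1.0-fold lower number from compound 2 to compound 3 (0.02 log units; that floor lies within the scatter) and it is an estimate only. Compound 3 is expected at 380 mL.min-1.g-1 with an estimated range from 240 mL.min-1.g-1 to 450 mL.min-1.g-1. Compound 3 may well give only a limit.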

Compound 3, intrinsic clearance in microsomes: > 399 mL.min-1.g-1
Compound 3: only a limit was reported; the forecaster's own chance of this, stated with the estimate: 50%; at least 1.0-fold (0.02 log units) between middle value and limit.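

In this assay, the group with the three-membered ring, entering in place of 4,4-dimethylpiperidin-1-yl on the aromatic carbon next to the ring nitrogen, does not bring compound 3 to a readable number. For the compounds shown here, compound 2 and compound 3 each carry a limit rather than a number, so the step between them cannot be read, and this change has no measurable size here: the limit of > 399 mL.min-1.g-1 in this assay, at which 2 of the 3 values shown sit. Compound 3 also gives the first comparison at the sulfonyl sulfur, where cyclopentyl in place of isopropyl shows an at least 1.0-fold higher number from compound 1 to compound 3 (0.02 log units; that floor lies within the scatter), and this floor does not set the true size of that change.

Going by these compounds, it remains open whether another group at this place, such as morpholin-4-yl or a piperazine, would give a number rather than a limit while cyclopentyl stays on the sulfonyl sulfur. Also open, on these data alone, is whether a methyl group on the sulfonyl sulfur, with the rest of compound 1 kept, would read differently from isopropyl in this assay.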